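The source may hold more compounds than are shown below. What is called first, only, known or untested is meant among the compounds shown, and "the series" means these compounds.

Measured so far:
compound 1 `CCOC(=O)C1=Cc2ccccc2OC1(OCc1cc(-c2ccc(C)cc2)no1)C(F)(F)F` — > 150000 nM
compound 2 `CCOC(=O)C1=Cc2ccccc2OC1(OCc1cc(-c2ccc(OC)cc2)no1)C(F)(F)F` — > 150000 nM
compound 3 `O=C(O)C1=Cc2ccccc2OC1(OCc1cc(-c2ccc(F)cc2)no1)C(F)(F)F` — 168000 nM

Among the measured compounds shown here, in a functional assay on DU-145 cells (Homo sapiens) for inhibition, read by MTT assay, with a stated time of 24 h (on this read-out lower numbers stand for stronger inhibition and higher numbers for weaker inhibition), compound 3 gives 168000 nM, the only plain number in the set. For compound 1 the value > 150000 nM is a limit of the assay, not a number. For compound 2 the value > 150000 nM is likewise a limit. Hence a step that the two limits leave unreadable from compound 1 to compound 2 cannot be read in size. Compound 4 `CCOC(=O)C1=Cc2ccccc2OC1(OCc1cc(-c2ccc(F)cc2)no1)C(F)(F)F` differs from compound 3 by ethyl in place of hydrogen on an oxygen next to a carbonyl group. For the measured compounds named here, no measured step follows this change directly; the two ester analogues, compound 1 and compound 2, both sit at the limit of > 150000 nM in this assay, at which 2 of the 3 values shown sit. Compound 4 is therefore expected at or around that limit, with a 1.1-fold higher number from compound 3 to compound 4 (0.03 log units; within the scatter) of no readable size. The estimate for compound 4 is 180000 nM, with a range from 100000 nM to 400000 nM.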

Compound 4, half-maximal inhibitory concentration: 53500 nM
For compound 4 the middle estimate is 3.4-fold (0.53 log units) above the measured one, outside the stated range (below it).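

In this assay, among the compounds shown here, the first readable change at this position is carboxy to ethoxycarbonyl, with a 3.1-fold lower number from compound 3 to compound 4 (0.50 log units; beyond the scatter). With the ethoxycarbonyl group held, the aromatic substituent also matters: fluoro in place of methoxy gives an at least 2.8-fold lower number from compound 2 to compound 4 (0.44 log units; beyond the scatter), and fluoro in place of methyl gives an at least 2.8-fold lower number from compound 1 to compound 4 (0.44 log units; beyond the scatter). Both of these steps start from a limit of the assay, not a number: the limit of > 150000 nM in this assay, at which 2 of the 4 values shown sit.

As far as these compounds go, whether a longer chain than ethyl on this oxygen lowers the number further remains open. So does whether chloro in place of fluoro on the aromatic carbon keeps the lower number.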